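A Dihydroxyphenethyl Ester Awaits Its Measurement

A few compounds are considered here, and "the series" means these few. Any claim that something is new, unique, unknown or untested is made for them only; others in the source may bear on it.

Compound 1 `C/C=C1/[C@H](O[C@@H]2O[C@H](CO)[C@@H](O)[C@H](O)[C@H]2O)OC=C(C(=O)OC)[C@H]1CC(=O)OC[C@H]1O[C@@H](OCCc2ccccc2)[C@H](O)[C@@H](O)[C@@H]1O` gives 65700 nM in a functional assay on RAW264.7 cells (Mus musculus) for inhibition, read by Griess assay, with a stated time of 24 h; on this read-out higher numbers stand for weaker inhibition and lower numbers for stronger inhibition. Compound 2 `C/C=C1/[C@H](O[C@@H]2O[C@H](CO)[C@@H](O)[C@H](O)[C@H]2O)OC=C(C(=O)OC)[C@H]1CC(=O)OC[C@H]1O[C@@H](Oc2ccc(/C=C/CO)cc2OC)[C@H](O)[C@@H](O)[C@@H]1O` gives > 80000 nM in this assay, which is a limit of the assay and not a number. Compound 3 `C/C=C1/[C@H](O[C@@H]2O[C@H](CO)[C@@H](O)[C@H](O)[C@H]2O)OC=C(C(=O)OC)[C@H]1CC(=O)OC` gives > 80000 nM in this assay, again a limit rather than a number.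

Compound 2 therefore stands at the upper edge of what was measured, with no number of its own. Among the measured compounds shown here, the one step that reaches it, an at least 1.2-fold higher number from compound 1 to compound 2 (0.08 log units; that floor lies within the scatter), has a floor that lies within the scatter, so it shows no real change from compound 1 to compound 2 (the limit of > 80000 nM in this assay, at which 2 of the 3 values shown sit).

Compound 4 `C/C=C1/[C@H](O[C@@H]2O[C@H](CO)[C@@H](O)[C@H](O)[C@H]2O)OC=C(C(=O)OC)[C@H]1CC(=O)OC[C@H]1O[C@@H](OCCc2ccc(O)c(O)c2)[C@H](O)[C@@H](O)[C@@H]1O` is the next ester in this line. It differs from compound 2 by 2-(3,4-dihydroxyphenyl)ethyl in place of 4-(3-hydroxyprop-1-en-1-yl)-2-methoxyphenyl on an oxygen on a saturated carbon. The new group returns to a two-carbon link of the kind found in compound 1, now carrying two hydroxyls on the ring. For the measured compounds named here, the only measured step bearing on this change is the one from compound 1 to compound 2, and it was not resolved beyond the scatter. Compound 4 is therefore expected to show an at least 1.1-fold lower number from compound 2 to compound 4 (0.05 log units; that floor lies within the scatter), a step no larger than the scatter, and it may well return only a limit. The estimate for compound 4 in this assay is 70000 nM, within 30000 nM to 160000 nM.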

Compound 4, half-maximal inhibitory concentration: 48900 nM
Beside the measured number, compound 4's estimate is 1.4-fold (0.16 log units) above it; the range from low to high includes it.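

Hydroxyl groups on the ring of the two-carbon group make no difference that can be read at this position in this assay. Setting 3,4-dihydroxyphenyl in place of phenyl on a saturated chain carbon, two bonds along the chain from an oxygen on a saturated carbon, gives a 1.3-fold lower number from compound 1 to compound 4 (0.13 log units; within the scatter), so the two rings cannot be told apart here. Putting 2-(3,4-dihydroxyphenyl)ethyl in place of 4-(3-hydroxyprop-1-en-1-yl)-2-methoxyphenyl gives an at least 1.6-fold lower number from compound 2 to compound 4 (0.21 log units; that floor lies within the scatter), and the full size of this step stays unknown because one end of it is a limit of the assay and not a number: the limit of > 80000 nM in this assay, at which 2 of the 4 values shown sit.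

The compounds shown leave open whether any group at this position can move the number in this assay beyond the scatter, since an amine or a carboxylic acid on the ring in place of the hydroxyls is not among them. As far as these compounds go, a longer chain in place of the ethyl link is also absent, so it remains unknown whether the length of the link matters at all.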